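The source may report more compounds than this note shows. Statements on the series, on what has been measured and on what is new or still open speak of the compounds shown alone.

Working notes on the series

Three compounds of this set have been run in an assay on HEK293 cells for agonist activity at Toll-like receptor 8 (Homo sapiens), read by spectrophotometry; a higher number here means that more compound is needed for the effect, a lower number that less compound is needed. Compound 1 `CCCCNc1nc(N)nc(C)c1CCCn1c(C)nc2ccccc21` gives 366 nM. Compound 2 `CCCCNc1nc(N)nc(C)c1C` gives 3280 nM. Compound 3 `CCCCNc1nc(N)nc(C)c1C#CCN1CCCCC1` gives 3790 nM. Compound 2 thus stands second highest of the three numbers: its number sits within the scatter of the value of compound 3, so no order can be read between those two, while compound 1 lies well below it, beyond the scatter.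

The next compound to be run is compound 4 `CCCCNc1nc(N)nc(C)c1CCCn1cccn1`. Relative to compound 2 the change is 2-(1H-pyrazol-1-yl)ethyl in place of hydrogen on a saturated chain carbon bound to an aromatic carbon. Among the measured compounds shown here, no pair differing in one place has yet been measured, so the size of this step rests on expectation alone. For the measured compounds named here, the only compound that carries a larger chain on that saturated carbon, compound 1, gives 366 nM, and on that basis a step downward, beyond the scatter, is expected for compound 4, as a 2.7-fold lower number from compound 2 to compound 4 (0.44 log units; beyond the scatter). Compound 4 is expected to give about 1200 nM in this assay, with a range from 400 nM to 3500 nM.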

Compound 4, half-maximal effective concentration: 1050 nM
Estimate against measurement, compound 4: 1.1-fold (0.06 log units) above, and the stated range covers the measured number.
By their numbers in this assay, from the lowest: compound 1; then compound 4; then compounds 2 and 3 (each within the scatter of the next).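

In this assay the series now has its first pair differing in one place, with a 3.1-fold lower number from compound 2 to compound 4 (0.49 log units; beyond the scatter) when 2-(1H-pyrazol-1-yl)ethyl replaces hydrogen on a saturated chain carbon bound to an aromatic carbon. This position therefore tolerates the entering group of 7 heavy atoms, and the step lies beyond the scatter, so the number responds measurably to a change at this place. No evidence is at hand that bears on the reason for this step.

From the compounds shown here alone, it remains open whether the step comes from the ethyl chain or from the pyrazole ring, which a plain ethyl or a 2-phenylethyl group at this place would help to separate. Going by these compounds, how a longer chain carrying the same ring, or an ethyl chain ending in a primary amine, would read also remains open.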